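The compounds below may be only part of what the source reports. "The series", "measured", "known", "first", "only" and "open" are said of these compounds alone.

Measured in an ADME assay on microsomes from liver (Rattus norvegicus) for metabolic stability, with a stated time of 60 min, tested at 1 uM; a higher number here means that more of the compound is left, a lower number that less of the compound is left:
- compound 1 `COc1cc(-c2cnn3cc(OC)c(-c4cc(C)no4)nc23)ccn1` gives 62%
- compound 2 `COc1cc(-c2cnn3cc(OC)c([C@@H]4COC(C)(C)C4)nc23)ccn1` gives 30%
- compound 3 `COc1cc(-c2cnn3cc(OC)c([C@H]4COC(C)(C)C4)nc23)ccn1` gives 30%

Compound 1 stands highest of the three. The nearest is compound 2, with a number 32 percentage points lower from compound 1 to compound 2 (beyond the scatter); the furthest is compound 3, with a number 32 percentage points lower from compound 1 to compound 3 (beyond the scatter). Between them there is no change at the digits printed from compound 2 to compound 3 (within the scatter), which fits because of the fact that compounds 2 and 3 differ only in the configuration as drawn.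

Compound 4 `COc1cc(-c2cnn3cc(OC)c(N(C)C)nc23)ccn1` differs from compound 1 by dimethylamino in place of 3-methyl-1,2-oxazol-5-yl on an aromatic carbon. Among the compounds with values here, the only measured step that bears on this place on the core is the exchange of the 3-methyl-1,2-oxazol-5-yl group, and in both instances it cost a large amount. A drop of similar size is therefore expected for compound 4, namely a number 24 percentage points lower from compound 1 to compound 4 (beyond the scatter). Compound 4 is estimated to give 38%, with a range from 15% to 65%.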

Compound 4, percent of the compound remaining: 3%
Estimate against measurement, compound 4: 35 percentage points above; measured number outside the range, below it.
By their numbers in this assay, from the lowest: compound 4; then compounds 2 and 3 (each within the scatter of the next); then compound 1.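

Dimethylamino, the group with no ring, leaves little of the compound in this assay at this place on the core, with a number 59 percentage points lower from compound 1 to compound 4 (beyond the scatter) and also a number 27 percentage points lower from compound 2 to compound 4 (beyond the scatter) and a number 27 percentage points lower from compound 3 to compound 4 (beyond the scatter). The heavy-atom count does not order these groups, since compounds 2 and 3 carry the largest group yet stand below compound 1, which keeps the 3-methyl-1,2-oxazol-5-yl group. Nothing measured here gives a reason for these drops. Still open, as far as these compounds go, is whether the low number follows from the amine nitrogen on the ring or from the lack of a ring. Morpholine or pyrrolidine at this place would separate the two.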